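Sulfanyl to sulfonyl change at compound 3

The source may hold more compounds than are shown below. What is called first, only, known or untested is meant among the compounds shown, and "the series" means these compounds.

Compound 3 (`O=C(/C(=C\c1c(O)cc(O)cc1O)Sc1ccccc1Br)c1ccc(Cl)cc1`) stands at > 100000 nM in a functional assay on DU-145 cells (Homo sapiens) for inhibition, read by trypan blue exclusion, with a stated time of 96 h (on this read-out higher numbers stand for weaker inhibition of growth and lower numbers for stronger inhibition of growth), a limit of the assay and not a number. The change to compound 4 (`Cc1ccc(S(=O)(=O)/C(=C/c2c(O)cc(O)cc2O)C(=O)c2ccc(Cl)cc2)cc1`) is (4-methylphenyl)sulfonyl in place of (2-bromophenyl)sulfanyl on a double-bonded chain carbon bound to a carbonyl carbon and a double-bonded chain carbon. Compound 1 (`O=C(/C(=C\c1c(O)cc(O)cc1O)S(=O)(=O)c1ccccc1Br)c1ccc(Cl)cc1`) gives 50000 nM and compound 2 (`O=C(/C(=C\c1c(O)cc(O)cc1O)Sc1ccc(Br)cc1)c1ccc(Cl)cc1`) gives 50000 nM, with no change at the digits printed from compound 1 to compound 2 (within the scatter). Two further steps bear on the change: an at least 2.0-fold higher number from compound 1 to compound 3 (0.30 log units; that floor lies within the scatter) and an at least 2.0-fold higher number from compound 2 to compound 3 (0.30 log units; that floor lies within the scatter). The (4-methylphenyl)sulfonyl shares its sulfonyl with compound 1 and its 4-substituted name with the (4-bromophenyl)sulfanyl of compound 2. A lower number is therefore expected, of a size not clearly beyond the scatter. The expected step is an at least 2.2-fold lower number from compound 3 to compound 4 (0.34 log units; beyond the scatter). Compound 4 is estimated at 45000 nM, with an expected range of 12000 nM to 100000 nM.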

Compound 4, concentration for 50% growth inhibition: > 100000 nM
Compound 4 gave a limit, no number; the forecaster's own chance of this, stated with the estimate: 20%; at least 2.2-fold (0.34 log units) between middle value and limit.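

In this assay compound 4 gives > 100000 nM, a limit of the assay and not a number. Compound 1 carries the sulfonyl and compound 2 a 4-substituted ring, and each gives a number, whereas the two together in compound 4 do not, with an at least 2.0-fold higher number from compound 1 to compound 4 (0.30 log units; that floor lies within the scatter) and an at least 2.0-fold higher number from compound 2 to compound 4 (0.30 log units; that floor lies within the scatter), both floors within the scatter. The step from compound 3 to compound 4 cannot be read, and the limit recurs in this short set: the limit of > 100000 nM in this assay, at which 2 of the 4 values shown sit.

On these data alone, whether a (4-aminophenyl)sulfonyl or a (4-carboxyphenyl)sulfonyl at this position would give a readable number stays open.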